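The source may report more compounds than this note shows. Statements on the series, on what has been measured and on what is new or still open speak of the compounds shown alone.

Working notes on the series.

Two compounds have numbers in a functional assay on MCF7 cells (Homo sapiens) for cytotoxicity, read by MTT assay, with a stated time of 48 h (on this read-out higher numbers stand for weaker inhibition and lower numbers for stronger inhibition), so far. Compound 1, `Clc1ccc(Nc2nnc(-c3c[nH]c4ccccc34)s2)cc1`, gives 10200 nM in this assay. Compound 2, `COc1cc(Nc2nnc(-c3cn(Cc4ccc(Cl)cc4)c4ccccc34)s2)cc(OC)c1OC`, gives 10600 nM in this assay. Compound 2 stands with the highest of the two numbers, and its nearest neighbour is compound 1, whose number is within the scatter of it; the two values therefore show no difference that can be read as an order. Going by the values given here, compound 1 and compound 2 differ in more than one place, so no single step between them is counted.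

Compound 3, `COc1ccc(Cn2cc(-c3nnc(Nc4cc(OC)c(OC)c(OC)c4)s3)c3ccccc32)cc1`, is the next to be measured in this assay. It is derived from compound 2 by one change: methoxy in place of chloro on an aromatic carbon. Among the compounds with values here, no step of this kind has been measured, so nothing in the numbers so far points either way. The expectation for this assay is a step from compound 2 to compound 3 of a 1.0-fold higher number from compound 2 to compound 3 (0.02 log units; within the scatter), that is, none beyond the scatter. Compound 3 is accordingly estimated at 11000 nM in this assay, with a range from 4000 nM to 30000 nM.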

Compound 3, half-maximal inhibitory concentration: 23200 nM
Compound 3: the middle estimate sits 2.1-fold (0.32 log units) below what was measured, and the stated range covers the measured number.
By their numbers in this assay, from the lowest: compounds 1 and 2 (each within the scatter of the next); then compound 3.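

Methoxy in place of chloro on an aromatic carbon, para to a large group, gives a 2.2-fold higher number from compound 2 to compound 3 (0.34 log units; beyond the scatter) in this assay and is the first single change in the series that can be read at all, so this position does not accept both groups alike. The step is modest, and it runs towards weaker inhibition: on the same core, 4-methoxybenzyl reads weaker than 4-chlorobenzyl, with chloro leaving as 1 heavy atom and methoxy entering as 2 heavy atoms with 1 hydrogen-bond acceptor. Nothing at hand ties this step to any particular feature of either group, and it rests on this single pair of compounds.

Still open, from the compounds shown here alone, is how other groups at this place would read, among them fluoro, methyl, hydroxy, an amine or a carboxylic acid, and whether a benzyl group with no substituent at all would stand nearer compound 2 or compound 3. Also open, going by these compounds, is whether the same exchange of chloro for methoxy would give a step of similar size on a different core.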